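Removal of the tosyl sulfonamide: compound 2 to compound 3

The source may hold more compounds than are shown below. What is called first, only, known or untested is meant among the compounds shown, and "the series" means these compounds.

Measured so far:
Compound 1 `Cc1ccc(S(=O)(=O)Nc2ccc3c(c2)C(=O)N(CCCCBr)C3=O)cc1` — > 200000 nM.
Compound 2 `Cc1ccc(S(=O)(=O)Nc2ccc3c(c2)C(=O)N(CCNc2ccccc2)C3=O)cc1` — 99600 nM.

The read-out throughout is an assay on isolated protein for inhibition of lysosomal alpha-glucosidase (Rattus norvegicus), read by colorimetric assay; a lower number here means a stronger inhibitor, a higher number a weaker inhibitor. Compound 1 gives only a limit, > 200000 nM, and no number. Among the compounds with values here, compound 2 gives 99600 nM, the only number in the set. The other value, that of compound 1, is a limit, (the limit of > 200000 nM in this assay, at which 1 of the 2 values shown sits). Within the data shown here, the one measured step, an at least 2.0-fold lower number from compound 1 to compound 2 (0.30 log units; that floor lies within the scatter), concerns the chain end only and leaves the sulfonamide untouched.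

Compound 3 `Nc1ccc2c(c1)C(=O)N(CCNc1ccccc1)C2=O` is the next compound. The change from compound 2 is hydrogen in place of (4-methylphenyl)sulfonyl on a nitrogen on an aromatic ring. Among the measured compounds shown here, no measured step touches this part of the shared core, so nothing in the numbers supports a direction for it. Both measured compounds are weak, and a large group is removed without replacement; the working assumption is a somewhat higher number, with a fair chance that only a limit is returned. The expected step is a 1.6-fold higher number from compound 2 to compound 3 (0.21 log units; within the scatter), which lies within the scatter. Compound 3 is therefore expected to give about 160000 nM, with a range from 40000 nM to 600000 nM.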

Compound 3, half-maximal inhibitory concentration: 144000 nM
For compound 3 the middle estimate is 1.1-fold (0.05 log units) above the measured one; the measured number falls inside the stated range.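

Within the data shown here, this is the first read on the nitrogen on an aromatic ring: in this assay, a 1.4-fold higher number from compound 2 to compound 3 (0.16 log units; within the scatter). The (4-methylphenyl)sulfonyl group, with its 10 heavy atoms, one six-membered aromatic ring and 2 hydrogen-bond acceptors, can therefore be replaced by hydrogen without a shift beyond the scatter. For this pair, inhibition at this weak level does not depend on that group, and compound 3 still returns a number rather than a limit, although nothing here shows that the position is without influence when other groups are placed on it.

Open, going by these compounds, is whether a different group on this nitrogen, such as an acetyl amide or a methyl group, or a longer chain carrying the anilino end, would give a step beyond the scatter. Compound 1 gives a limit and no number, so the full size of the step at the chain end remains unread: the limit of > 200000 nM in this assay, at which 1 of the 3 values shown sits.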